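A few compounds are considered here, and "the series" means these few. Any claim that something is new, unique, unknown or untested is made for them only; others in the source may bear on it.

Compound 1 `COc1cc(-c2cc(/C=C/C(=O)c3ccc(N)cc3)[nH]n2)cc(OC)c1OC` was tested in a functional assay on OVCAR-8 cells (Homo sapiens) for cytotoxicity, read by sulforhodamine B assay, with a stated time of 48 h, tested at 0.01 uM (a higher number here means a weaker effect of the compound at the concentration tested, a lower number a stronger effect), and gave 100%. Two related compounds were measured alongside it: compound 2 `COc1ccc(-c2cc(/C=C/C(=O)c3ccc(OC)c(OC)c3)[nH]n2)cc1` gave 93%, and compound 3 `COc1ccc(-c2cc(/C=C/C(=O)c3ccc(N)cc3)[nH]n2)cc1` gave 96%. Compound 1 carries the largest of the three numbers, but its gaps to compound 3 and to compound 2 both lie within the usual scatter, so the three compounds cannot be told apart in this assay at the concentration tested; all three leave the cells essentially unaffected.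

The next compound, compound 4 `COc1cc(-c2cc(/C=C/C(=O)c3ccc(F)c(F)c3)[nH]n2)cc(OC)c1OC`, is derived from compound 1 by a single change on the carbonyl carbon whose other neighbour is a double-bonded chain carbon: 3,4-difluorophenyl in place of 4-aminophenyl on a carbonyl carbon

Among the measured compounds shown here, no pair of measured compounds differs in one place only, so there is no measured step to lean on. Given that compound 1 sits at 100% and the other two compounds sit within the scatter of it, compound 4 is expected to behave likewise, with a step of a number 3 percentage points lower from compound 1 to compound 4 (within the scatter) that stays inside the scatter. Compound 4 is therefore estimated at 97%, within a range from 85% to 105%.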

Compound 4, a percentage reported as activity, at one concentration (the size of the read-out at that concentration, not a potency): 95%
Beside the measured number, compound 4's estimate is 2 percentage points above it, within the range that was stated.
By their numbers in this assay, from the lowest: compounds 2, 4, 3 and 1 (each within the scatter of the next).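

In this assay the first one-place change gives a number 5 percentage points lower from compound 1 to compound 4 (within the scatter) and so stays within the scatter. On the carbonyl carbon whose other neighbour is a double-bonded chain carbon, 3,4-difluorophenyl and 4-aminophenyl therefore cannot be told apart at the concentration tested, although the entering group has 0 hydrogen-bond donors and 0 hydrogen-bond acceptors and the leaving group has 1 hydrogen-bond donor and 1 hydrogen-bond acceptor. Nothing available explains why the two groups read alike.

On these data alone, it remains open whether a carboxylic acid or a longer alkyl chain on this carbonyl carbon would give a read-out outside the scatter of compound 1. As far as these compounds go, it is also open whether compound 1 and compound 4 would separate at a higher concentration than the one used here.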